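Swapping an aromatic amide cap for a saturated ring

The source may hold more compounds than are shown below. What is called first, only, known or untested is meant among the compounds shown, and "the series" means these compounds.

Of the compounds shown here, three with a shared core have been tested in a functional assay on Ramos cells (Homo sapiens) for antiproliferative activity, read by CCK-8 assay, with a stated time of 72 h, tested at 40 uM; on this read-out lower numbers stand for less inhibition and higher numbers for more inhibition at the one concentration tested (going by the name of the read-out). Compound 1 `CCOC(=O)c1sc(-c2cccc(NC(=O)c3ccc(F)cc3)c2)nc1Nc1ccc(N2CCN(C)CC2)cc1` gives 3.53%. Compound 2 `CCOC(=O)c1sc(-c2cccc(NC(=O)c3ccc(C#N)cc3)c2)nc1Nc1ccc(N2CCN(C)CC2)cc1` gives 97.5%. Compound 3 `CN1CCN(c2ccc(Nc3nc(-c4cccc(NC(=O)c5ccc(F)cc5)c4)sc3C(N)=O)cc2)CC1` gives 95.9%, which places it second highest of the three; its gap to compound 2 lies within the scatter, so the two are not told apart, while the step of a number 92.4 percentage points higher from compound 1 to compound 3 (beyond the scatter) lies far beyond it.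

Compound 4 `CN1CCN(c2ccc(Nc3nc(-c4cccc(NC(=O)[C@H]5CC[C@H](C)CC5)c4)sc3C(N)=O)cc2)CC1` differs from compound 3 in one place: 4-methylcyclohexyl in place of 4-fluorophenyl on a carbonyl carbon. Going by the values given here, no measured step involves this change directly. The step of a number 94 percentage points higher from compound 1 to compound 2 (beyond the scatter) shows that altering the 4-fluorophenyl region can shift the read-out enormously, and the step of a number 92.4 percentage points higher from compound 1 to compound 3 (beyond the scatter) shows the same for the carbonyl group on the core. Both steps are large, so compound 4 cannot be assumed to keep the number of compound 3, yet neither step points in a direction for a saturated ring entering.

Given this, a moderate drop from compound 3 is expected as the middle guess, with a wide range: compound 4 is estimated at 60%, between 8% and 98%, meaning an expected step of a number 35.9 percentage points lower from compound 3 to compound 4 (beyond the scatter).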

Compound 4, a percentage reported as inhibition, at one concentration (the size of the read-out at that concentration, not a potency): 55.1%
Beside the measured number, compound 4's estimate is 4.9 percentage points above it; measured number inside the range.
By their numbers in this assay, from the lowest: compound 1; then compound 4; then compounds 3 and 2 (each within the scatter of the next).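

In this assay, a change at this position now has a measured effect with the amino group on the core's carbonyl held fixed: 4-methylcyclohexyl in place of 4-fluorophenyl gives a number 40.8 percentage points lower from compound 3 to compound 4 (beyond the scatter), a large step. The earlier steps shown here showed that this region could shift the read-out, but only through a cyano-for-fluoro swap on an aromatic ring; this one shows that replacing the aromatic ring with a non-aromatic ring of the same heavy-atom count lowers inhibition without abolishing it, with compound 4 at 55.1%. Nothing measured here bears on why the number falls, and the swap changes several things at once: the ring loses its aromaticity, fluorine is lost, a methyl group enters and two defined stereocentres appear.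

The compounds shown leave open which of those changes accounts for the step, a question that a plain phenyl, an unsubstituted cyclohexyl or a 4-methylphenyl cap could help to separate. They also leave open whether the stereoisomer of the 4-methylcyclohexyl group would give a similar number, and how a ring containing nitrogen, such as piperidine, would behave at this position.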